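A few compounds are considered here, and "the series" means these few. Any claim that something is new, unique, unknown or untested is made for them only; others in the source may bear on it.

Working notes on the series. Compound 1 `COc1ccc(N)c(C(=O)CCNC(C)=O)c1` gives 30.7% in an assay for inhibition of Nitric oxide synthase, inducible (Homo sapiens), read by scintillation counting, with a stated time of 30 min, tested at 1 mM; on this read-out lower numbers stand for less inhibition and higher numbers for more inhibition at the one concentration tested (going by the name of the read-out). Compound 2 `COc1ccc(N)c(C(=O)CCNC(=O)C2CC2)c1` gives 2.66% in this assay, and compound 3 `CC(=O)NCCC(=O)c1cc(Cl)ccc1N` gives 19.7%. Compound 3 therefore stands second highest of the three numbers. The nearer gap is a number 11 percentage points lower from compound 1 to compound 3 (beyond the scatter). The other gap, to compound 2, is larger and likewise beyond the scatter.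

The next compound, compound 4 `Nc1ccc(Cl)cc1C(=O)CCNC(=O)C1CC1`, is still to be measured in this assay. Its difference from compound 3: cyclopropyl in place of methyl on a carbonyl carbon. The same change has already been run once in this set, in the methoxy pair: a number 28 percentage points lower from compound 1 to compound 2 (beyond the scatter). Among the measured compounds shown here, that is the only measured step that bears on the question; no other pair shows the same change. On that single precedent a drop of comparable size is expected for compound 4, a number 15.7 percentage points lower from compound 3 to compound 4 (beyond the scatter), with the low starting point of compound 3 leaving less room for the number to fall. Compound 4 is accordingly estimated at 4% in this assay, within a range of -6% to 16%.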

Compound 4, a percentage reported as inhibition, at one concentration (the size of the read-out at that concentration, not a potency): 5.37%
For compound 4 the middle estimate is 1.4 percentage points below the measured one, and the stated range covers the measured number.
By their numbers in this assay, from the lowest: compounds 2 and 4 (each within the scatter of the next); then compound 3; then compound 1.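

Cyclopropyl in place of methyl on a carbonyl carbon now gives a second fall in this assay, a number 14.3 percentage points lower from compound 3 to compound 4 (beyond the scatter), so the change lowers the number on the chloro core as well as on the methoxy core: the same change on two cores in this assay, a number 28 percentage points lower (beyond the scatter) from compound 1 to compound 2 and a number 14.3 percentage points lower (beyond the scatter) from compound 3 to compound 4, 13.7 percentage points apart, within the scatter of two such steps.

With cyclopropyl on that carbonyl carbon, chloro in place of methoxy on an aromatic carbon gives a number 2.7 percentage points higher from compound 2 to compound 4 (within the scatter), whereas the same swap with methyl there gave a step beyond the scatter: the same change on two cores in this assay, a number 11 percentage points lower (beyond the scatter) from compound 1 to compound 3 and a number 2.7 percentage points higher (within the scatter) from compound 2 to compound 4, 13.7 percentage points apart, within the scatter of two such steps.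

Since both gaps between paired steps lie within the scatter, neither change can be said to differ in size from one core to the other.

Open, on these data alone, is whether the fall follows the three-membered ring or only the larger group, which an ethyl or isopropyl group on the same carbonyl carbon would help to separate. Also open, as far as these compounds go, is how fluoro or a hydroxyl group would read on the aromatic carbon that carries chloro or methoxy.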